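Cytotoxicity notes: the step from compound 3 to compound 4

The compounds below may be only part of what the source reports. "The series", "measured", "known", "first", "only" and "open" are said of these compounds alone.

Measured in an ADME assay on cells (Homo sapiens) for cytotoxicity, read by polymerase chain reaction, with a stated time of 3 days; a lower number here means that less compound is tolerated, a higher number that more compound is tolerated:
compound 1 `CNc1nc(C)c(-c2nc3ccccc3s2)c(N[C@@H]2C[C@H](CO)[C@@H](O)[C@H]2O)n1` gives the assay limit > 25000 nM.
compound 2 `Cc1nc(NCC2CCC2)nc(N[C@@H]2C[C@H](CO)[C@@H](O)[C@H]2O)c1-c1nc2ccccc2s1` gives the assay limit > 25000 nM.
compound 3 `CCOC(=O)NCCNc1nc(C)c(-c2nc3ccccc3s2)c(N[C@@H]2C[C@H](CO)[C@@H](O)[C@H]2O)n1` gives 12000 nM.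

Going by the values given here, compound 3 holds the only number in this assay; the other two values are limits, (the limit of > 25000 nM in this assay, at which 2 of the 3 values shown sit). The change to compound 4 `Cc1nc(Nc2ncco2)nc(N[C@@H]2C[C@H](CO)[C@@H](O)[C@H]2O)c1-c1nc2ccccc2s1` is 1,3-oxazol-2-yl in place of 2-((ethoxycarbonyl)amino)ethyl on a nitrogen on an aromatic ring. The step of an at least 2.0-fold lower number from compound 1 to compound 3 (0.31 log units; beyond the scatter) and the step of an at least 2.0-fold lower number from compound 2 to compound 3 (0.31 log units; beyond the scatter) both bear on it, as each marks the arrival of the group that now leaves; the step that the two limits leave unreadable from compound 1 to compound 2 is unreadable. Removing that group is expected to move compound 4 back toward the limit, an estimated step of a 2.1-fold higher number from compound 3 to compound 4 (0.32 log units; beyond the scatter). Compound 4 is estimated at 25000 nM, within 9000 nM to 60000 nM, with a limit again a likely outcome.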

Compound 4, half-maximal cytotoxic concentration: > 25000 nM
Compound 4 was reported as a limit; the forecaster's own chance of this, stated with the estimate: 55%; the middle value sits exactly at the limit.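

Compound 4 puts a five-membered aromatic ring on this nitrogen, where compound 1, compound 2 and compound 3 carry no aromatic group, and in this assay the change gives an at least 2.0-fold higher number from compound 3 to compound 4 (0.31 log units; beyond the scatter). Among the compounds shown, a readable number therefore stays confined to the 2-((ethoxycarbonyl)amino)ethyl group, and the aromatic ring does not produce one. The steps to compound 4 from compound 1 and from compound 2 cannot be read: the limit of > 25000 nM in this assay, at which 3 of the 4 values shown sit.

From the compounds shown here alone, whether a 2-aminoethyl or 2-hydroxyethyl chain on this nitrogen would also give a number in this assay stays open. So does whether the ethoxycarbonyl part or the chain itself goes with the lower number of compound 3.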